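The source may report more compounds than this note shows. Statements on the series, on what has been measured and on what is new or still open speak of the compounds shown alone.

For the measured compounds named here, compound 1 `CC1=C(/C=C/C(=O)/C=C/c2ccc(F)cc2)C(C)(C)CCC1` stands highest of the two numbers so far in a functional assay on PC-3 cells (Homo sapiens) for cytotoxicity, read by sulforhodamine B assay, with a stated time of 48 h (a lower number here means a stronger inhibitor, a higher number a weaker inhibitor), where compound 1 gives 8200 nM. Compound 2 `CC1=C(/C=C/C(=O)/C=C/c2ccc([N+](=O)[O-])cc2)C(C)(C)CCC1` gives 1900 nM in this assay, a step of a 4.3-fold lower number from compound 1 to compound 2 (0.64 log units; beyond the scatter) from a nitro in place of fluoro on an aromatic carbon. Compound 3 `CC1=C(/C=C/C(=O)/C=C/c2ccoc2)C(C)(C)CCC1` differs from compound 1 by furan-3-yl in place of 4-fluorophenyl on a double-bonded chain carbon bound to a double-bonded chain carbon. Going by the values given here, no measured step exchanges the whole ring, and the one step known shows only that a change at this end moves the number modestly. For compound 3 no step beyond the scatter is expected, a 1.2-fold higher number from compound 1 to compound 3 (0.09 log units; within the scatter), with an estimate of 10000 nM between 4000 nM and 25000 nM.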

Compound 3, half-maximal inhibitory concentration: 50300 nM
For compound 3 the middle estimate is 5.0-fold (0.70 log units) below the measured one, and the stated range ends below it.
By their numbers in this assay, from the lowest: compound 2; then compound 1; then compound 3.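

Replacing the whole ring at this end also moves the number, with a 6.1-fold higher number from compound 1 to compound 3 (0.79 log units; beyond the scatter) in this assay. Together with the earlier nitro step, which lowered the number, this shows that changes at this end of compound 1 can shift cytotoxicity in either direction. No measurement shown here accounts for the change.

Still open, from the compounds shown here alone, is whether an unsubstituted phenyl ring would stay close to compound 1 or fall toward compound 3. Going by these compounds, it is also open how a pyridine ring or a thiophene ring would behave at this position.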